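This account rests on a few compounds, and the source may have more. Where it says the series, first, only, none or still open, it means among the compounds named here.

Three analogues of one shared core have been examined in an assay on isolated protein (Mus musculus) for inhibition of IL15-IL15 receptor (Homo sapiens), read by resazurin assay, with stated times of 30 min and 2.5 days; on this read-out higher numbers stand for weaker inhibition and lower numbers for stronger inhibition. Compound 1 `Cn1c(Cc2nn(C)c(=O)c3ccccc23)nnc1SCC(=O)Nc1ccc(O)cc1` gives "not active" (no number reported) in this assay, so no number stands for it. Compound 2 `CC(C)COc1ccc(NC(=O)CSc2nnc(Cc3nn(C)c(=O)c4ccccc34)n2C)cc1` gives 30000 nM in this assay. Compound 3 `Cn1c(Cc2nn(C)c(=O)c3ccccc23)nnc1SCC(=O)Nc1ccc(Cl)cc1Cl` gives 17300 nM in this assay. Among the compounds with values here, these are the only two numbers, and the step of a 1.7-fold lower number from compound 2 to compound 3 (0.24 log units; within the scatter) lies within the scatter of repeated measurement, so the two compounds cannot be set apart on this evidence.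

Compound 4 `COc1ccc(NC(=O)CSc2nnc(Cc3nn(C)c(=O)c4ccccc34)n2C)cc1` has not yet been measured. It differs from compound 3 by 4-methoxyphenyl in place of 2,4-dichlorophenyl on an amide-type nitrogen. Within the data shown here, the one measured step that bears on this change is the exchange of one aryl group for another on the same amide-type nitrogen, a 1.7-fold lower number from compound 2 to compound 3 (0.24 log units; within the scatter), which did not exceed the scatter. On that basis the step from compound 3 to compound 4 is expected to be a 1.3-fold higher number from compound 3 to compound 4 (0.10 log units; within the scatter), that is, no change beyond the scatter. Compound 4 is therefore expected to give about 22000 nM in this assay, within a range from 8000 nM to 60000 nM.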

Compound 4, half-maximal inhibitory concentration: "not active" (no number reported)
For compound 4 the study gives words and no number; there is nothing to compare the estimate with.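

Within the data shown here, compound 4 is reported in words only, so no step from compound 3 to compound 4 can be read. No evidence shown accounts for this result. The compounds shown leave open whether any exchange of the aryl group on the amide-type nitrogen changes inhibition beyond the scatter.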